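Compound 3 to compound 4: fluoro in place of nitro

This account rests on a few compounds, and the source may have more. Where it says the series, first, only, none or still open, it means among the compounds named here.

Measured so far in a functional assay on MCF7 cells (Homo sapiens) for antiproliferative activity, read by MTT assay, with a stated time of 72 h (on this read-out higher numbers stand for weaker inhibition and lower numbers for stronger inhibition), as the read-out:
compound 1 `CC1=CC[C@H]2[C@H](CC[C@]2(C)O)C(C)(C)[C@@H]1CC[C@H]1[C@]2(C)CC[C@H](OC(=O)NS(=O)(=O)c3ccc(C)cc3)C(C)(C)O[C@H]2CC[C@@]1(C)O` gives > 50000 nM here
compound 2 `CC1=CC[C@H]2[C@H](CC[C@]2(C)O)C(C)(C)[C@@H]1CC[C@H]1[C@]2(C)CC[C@H](OC(=O)c3cccc([N+](=O)[O-])c3)C(C)(C)O[C@H]2CC[C@@]1(C)O` gives 36000 nM here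
compound 3 `CC1=CC[C@H]2[C@H](CC[C@]2(C)O)C(C)(C)[C@@H]1CC[C@H]1[C@]2(C)CC[C@H](OC(=O)c3ccccc3[N+](=O)[O-])C(C)(C)O[C@H]2CC[C@@]1(C)O` gives 5200 nM here

For compound 1 the entry > 50000 nM is a limit of the assay and not a number. Compound 3 holds the lower of the two true numbers, after a 6.9-fold lower number from compound 2 to compound 3 (0.84 log units; beyond the scatter) (beyond the scatter). Against the limit, an at least 9.6-fold lower number from compound 1 to compound 3 (0.98 log units; beyond the scatter) is only a floor.

Compound 4 `CC1=CC[C@H]2[C@H](CC[C@]2(C)O)C(C)(C)[C@@H]1CC[C@H]1[C@]2(C)CC[C@H](OC(=O)c3ccccc3F)C(C)(C)O[C@H]2CC[C@@]1(C)O` is the next structure, with fluoro in place of nitro on an aromatic carbon, ortho to a large group fluoro in place of nitro on an aromatic carbon in the comparison with compound 3. Going by the values given here, no measured step makes this exchange. The closest guide is compound 3 itself, where a 6.9-fold lower number from compound 2 to compound 3 (0.84 log units; beyond the scatter) shows that the number in this assay moves with the place of the nitro group. Part of that gain may be lost once nitro leaves, so a modest step towards a higher number is expected, with the direction uncertain. The expected change is a 1.9-fold higher number from compound 3 to compound 4 (0.28 log units; within the scatter) on this reasoning. For compound 4 the estimated value is 10000 nM with an expected range of 3000 nM to 32000 nM in this estimate.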

Compound 4, half-maximal inhibitory concentration: 11300 nM
Beside the measured number, compound 4's estimate is 1.1-fold (0.05 log units) below it; measured number inside the range.
By their numbers in this assay, from the lowest: compound 3; then compound 4; then compound 2. At a limit, above all of these: compound 1.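

Going by these compounds alone, the first exchange of the nitro group itself at this place, in this assay, shows that the number does not rest on nitro alone: a 2.2-fold higher number from compound 3 to compound 4 (0.34 log units; beyond the scatter), a modest step, so 2-fluorophenyl gives up only part of what 2-nitrophenyl gives. Compound 4 also keeps a lower number than the 3-nitrophenyl compound, a 3.2-fold lower number from compound 2 to compound 4 (0.50 log units; beyond the scatter), though that step changes the group and its place together, so compounds 3 and 4, each with a group ortho to a large group, both lie below compound 2. Compound 1 stands at a limit and not at a number, so an at least 4.4-fold lower number from compound 1 to compound 4 (0.64 log units; beyond the scatter) is only a floor: the limit of > 50000 nM in this assay, at which 1 of the 4 values shown sits.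

On these data alone, whether any group at this place is needed stays open, and plain phenyl, 2-aminophenyl or 2-methoxyphenyl on the same carbonyl would address that. Also open, as far as these compounds go, is whether 3-fluorophenyl would sit above 2-fluorophenyl as 3-nitrophenyl sits above 2-nitrophenyl.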